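Trimming the Amine Substituent on the Piperidine Ring

A few compounds are considered here, and "the series" means these few. Any claim that something is new, unique, unknown or untested is made for them only; others in the source may bear on it.

Of the compounds shown here, three built on a shared core have been measured in an assay on CHO cells for displacement of a labelled ligand from 5-hydroxytryptamine receptor 1D (Homo sapiens); on this read-out higher numbers stand for weaker inhibition and lower numbers for stronger inhibition. Compound 1 `COC[C@H](NC1CCN(CCCc2c[nH]c3ccc(Cn4cncn4)cc23)CC1)c1ccc(F)cc1` gives 5 nM, compound 2 `O[C@H]1Cc2ccccc2C1NC1CCN(CCCc2c[nH]c3ccc(-n4cnnc4)cc23)CC1` gives 37 nM, and compound 3 `c1ccc(C2CCCCN2C2CCN(CCCc3c[nH]c4ccc(-n5cnnc5)cc34)CC2)cc1` gives 1.9 nM. Compound 2 therefore stands at the highest number of the three, meaning the weakest inhibition; its nearest neighbour is compound 1, whose value lies lower by a margin beyond the usual scatter, and compound 3 lies lower still.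

Compound 4 `CC(C)=CCN(C)C1CCN(CCCc2c[nH]c3ccc(-n4cnnc4)cc23)CC1` has not yet been measured. It differs from compound 2 in a single place: methyl(3-methylbut-2-en-1-yl)amino in place of (2-hydroxy-2,3-dihydro-1H-inden-1-yl)amino on a saturated ring carbon. The group that leaves carries two rings and two hydrogen-bond donors; the group that enters has no ring, one double bond outside aromatic rings and no hydrogen-bond donor.

Within the data shown here, no step between two measured compounds isolates this change, so the expectation rests on the spread of the three values. Among the measured compounds shown here, compound 2 is the only one bearing the hydroxy-indanyl group, and it is also the weakest, while compound 3 at 1.9 nM and compound 1 at 5 nM show that other substituents on that saturated ring carbon give stronger binding. A move toward lower numbers is therefore expected from compound 2 to compound 4, likely beyond the scatter, as a 3.7-fold lower number from compound 2 to compound 4 (0.57 log units; beyond the scatter) expresses. Compound 4 is estimated at 10 nM, with a likely range from 3 nM to 40 nM.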

Compound 4, half-maximal inhibitory concentration: 0.5 nM
For compound 4 the middle estimate is 20-fold (1.30 log units) above the measured one; measured number outside the range, below it.
By their numbers in this assay, from the lowest: compound 4; then compound 3; then compound 1; then compound 2.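

In this assay, putting methyl(3-methylbut-2-en-1-yl)amino in place of (2-hydroxy-2,3-dihydro-1H-inden-1-yl)amino gives a 74-fold lower number from compound 2 to compound 4 (1.87 log units; beyond the scatter), a large step and the only one here that isolates a change at this saturated ring carbon of the shared core. It shows that strong binding does not require either ring of the group that leaves, or any hydrogen-bond donor in the substituent at this place, since the smaller entering group has no ring and no donor yet gives a far lower number. No measurement shown here explains the size of this step.

This single step changes several things at once: both rings and the hydroxyl group go, while an N-methyl group and a double bond arrive, so the compounds shown cannot tell which of these differences matters most. A saturated 3-methylbutyl chain on the same nitrogen would test the double bond, and an indan-1-ylamino group without the hydroxyl would test the role of that hydroxyl group.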